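Swapping the cyanocyclopropyl group for a cyano-methylpyrrolidinyl ring

The source may report more compounds than this note shows. Statements on the series, on what has been measured and on what is new or still open speak of the compounds shown alone.

Measured compounds:
- compound 1 `CC1CCC(C[C@H](CC(=O)N2CCOCC2)C(=O)N[C@]2(C#N)CCN(C3CCCCC3)C2)CC1`: 13.8 nM
- compound 2 `N#C[C@@]1(NC(=O)[C@@H](CC(=O)N2CCOCC2)CC2CCCCC2)CCN(C2CCCC2)C1`: "not determined" (no result reported)
- compound 3 `N#CC1(NC(=O)[C@@H](CC(=O)N2CCOCC2)CC2CCCCC2)CC1`: 12 nM

In an assay on isolated protein for inhibition of cathepsin S (Homo sapiens) (on this read-out higher numbers stand for weaker binding and lower numbers for tighter binding), compound 3 gives 12 nM, and compound 1 gives 13.8 nM, the two numbers lying within the usual scatter of each other, so neither can be called the tighter binder. Compound 2 carries no reported result in this assay, its entry reading "not determined" (no result reported), and offers no comparison.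

Compound 4 `CN1CC[C@@](C#N)(NC(=O)[C@@H](CC(=O)N2CCOCC2)CC2CCCCC2)C1` differs from compound 3 in one place: 3-cyano-1-methylpyrrolidin-3-yl in place of 1-cyanocyclopropyl on an amide-type nitrogen. Going by the values given here, no measured pair shows this change, so the expected step from compound 3 to compound 4 in this assay is small, probably within the scatter, with a lean toward a slightly higher number: a 1.7-fold higher number from compound 3 to compound 4 (0.22 log units; within the scatter). Compound 4 is therefore estimated at 20 nM, with a range from 6 nM to 70 nM.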

Compound 4, dissociation constant: 161 nM
Compound 4: middle estimate off by 8.1-fold (0.91 log units), on the low side; measured number above the stated range.
By their numbers in this assay, from the lowest: compounds 3 and 1 (each within the scatter of the next); then compound 4.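

In this assay, the group on the amide-type nitrogen proves to matter: 3-cyano-1-methylpyrrolidin-3-yl in place of 1-cyanocyclopropyl gives a 13-fold higher number from compound 3 to compound 4 (1.13 log units; beyond the scatter), a large step beyond the scatter. Going by these compounds alone, the earlier compounds offered no single-place comparison, so this is the first sign that this position is sensitive to such a change. Nothing given here explains the size of the step.

This one pair cannot separate the larger ring from its ring nitrogen and methyl group. A 1-cyanocyclobutyl group or a 3-cyanotetrahydrofuran-3-yl group at this position could help tell these apart.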